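The source may report more compounds than this note shows. Statements on the series, on what has been measured and on what is new or still open speak of the compounds shown alone.

Compound 1 `COc1cc(N(CC2CC2)c2ccc(F)c3ccccc23)cnc1C(=O)[C@H]1C[C@@H]1C(=O)O` and compound 2 `COc1cc(N(CC(C)C)c2ccc(F)c3ccccc23)cnc1C(=O)[C@H]1C[C@@H]1C(=O)O` are built on one core, while compound 3 `COc1cc(N(CC2CC2)c2cc(Cl)c(F)cc2F)cnc1C(=O)[C@H]1C[C@@H]1C(=O)O` and the still unmeasured compound 4 `COc1cc(N(CC(C)C)c2cc(Cl)c(F)cc2F)cnc1C(=O)[C@H]1C[C@@H]1C(=O)O` are built on another; the difference between the two cores is not broken down here. In an assay on isolated protein for inhibition of leukotriene C4 synthase (Homo sapiens), read by LC-MS, with stated times of 45 min and 20 min (on this read-out lower numbers stand for stronger inhibition and higher numbers for weaker inhibition), compound 1 gives 26.5 nM, and compound 2 gives 2.26 nM. Among the compounds with values here, the single change separating them is isopropyl in place of cyclopropyl on a saturated chain carbon bound to a nitrogen on an aromatic ring, and it yields a 12-fold lower number from compound 1 to compound 2 (1.07 log units; beyond the scatter). In this assay compound 3 gives 27.6 nM, a value within the scatter of that of compound 1, whereas the gap between compound 3 and compound 2 lies beyond the scatter. Within the data shown here, compound 4 is related to compound 3 by isopropyl in place of cyclopropyl on a saturated chain carbon bound to a nitrogen on an aromatic ring, which is the same change, made at the same place, as the one that separates compound 1 from compound 2. The step from compound 3 to compound 4 is expected to be a 6.9-fold lower number from compound 3 to compound 4 (0.84 log units; beyond the scatter), a little smaller than the earlier one, because a 12-fold lower number from compound 1 to compound 2 (1.07 log units; beyond the scatter) was large and clearly beyond the scatter, while it is not known whether a step of that full size carries from one core to the other. Starting from the value of compound 3, compound 4 is therefore expected to give 4 nM in this assay. The estimated range for compound 4 runs from 1.5 nM to 12 nM.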

Compound 4, half-maximal inhibitory concentration: 8.5 nM
Beside the measured number, compound 4's estimate is 2.1-fold (0.33 log units) below it; the range from low to high includes it.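

In this assay, isopropyl in place of cyclopropyl on a saturated chain carbon bound to a nitrogen on an aromatic ring also lowers the number on the second core, giving a 3.2-fold lower number from compound 3 to compound 4 (0.51 log units; beyond the scatter), so the direction of the change carries over, but its full size does not: the same change on two cores in this assay, a 12-fold lower number (1.07 log units; beyond the scatter) from compound 1 to compound 2 and a 3.2-fold lower number (0.51 log units; beyond the scatter) from compound 3 to compound 4, 3.6-fold (0.56 log units) apart, beyond the scatter of two such steps Within this series, then, the change can be expected to favour the isopropyl compound on both cores shown, while the size of the step measured on one core cannot simply be transferred to the other. Within the data shown here, this rests on only two matched pairs, and it does not show which part of the difference between the two cores goes with the smaller step, nor whether the same direction would hold on any further core.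

The compounds shown leave open how a longer chain or a cyclobutyl ring would read at the same place, on a saturated chain carbon bound to a nitrogen on an aromatic ring, on either core. They also leave open whether the same change on a third core would come closer to the larger step or to the smaller one.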